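Swapping an aminopyridine for a triazole at the aryl tail

The source may hold more compounds than are shown below. What is called first, only, known or untested is meant among the compounds shown, and "the series" means these compounds.

Three compounds share one core and differ only in the ring attached to the phenyl group. In a functional assay on HEK293 cells for agonist activity at Bombesin receptor subtype-3 (Homo sapiens), read by luminescence and calcium flux, with a stated time of 10 min (on this read-out higher numbers stand for an effect only at larger amounts of compound and lower numbers for an effect already at smaller amounts), compound 1 `CCC(C)(C)Cc1c[nH]c(CCc2ccc(-n3cccn3)cc2)n1` gives 135 nM, compound 2 `CCC(C)(C)Cc1c[nH]c(CCc2ccc(-c3ccc(F)cn3)cc2)n1` gives 66 nM, and compound 3 `CCC(C)(C)Cc1c[nH]c(CCc2ccc(-c3cccc(N)n3)cc2)n1` gives 37 nM. Compound 3 thus stands at the low end of the three numbers: compound 2 lies within the scatter of it, while compound 1 sits beyond, as the step of a 3.6-fold lower number from compound 1 to compound 3 (0.56 log units; beyond the scatter) shows. Compound 4 `CCC(C)(C)Cc1c[nH]c(CCc2ccc(-n3cncn3)cc2)n1` is the next step, in which (1H-1,2,4-triazol-1-yl in place of 6-aminopyridin-2-yl on an aromatic carbon). The new group resembles the pyrazolyl ring of compound 1 more than the aminopyridyl ring of compound 3, so the steps of a 3.6-fold lower number from compound 1 to compound 3 (0.56 log units; beyond the scatter) and a 2.0-fold lower number from compound 1 to compound 2 (0.31 log units; beyond the scatter) are the relevant ones, and their direction is expected to reverse. Compound 4 is therefore expected to give a higher number in this assay, estimated at 180 nM with a range from 70 nM to 450 nM, because compound 1 gives 135 nM. The expected step is a 4.9-fold higher number from compound 3 to compound 4 (0.69 log units; beyond the scatter).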

Compound 4, half-maximal effective concentration: 570 nM
The estimate for compound 4 lay 3.2-fold (0.50 log units) below the measured number; measured number outside the range, above it.
By their numbers in this assay, from the lowest: compounds 3 and 2 (each within the scatter of the next); then compound 1; then compound 4.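

In this assay, among the compounds shown here, the ring at this position, on an aromatic carbon para to a large group, matters more than the first three compounds revealed: 1H-1,2,4-triazol-1-yl in place of 6-aminopyridin-2-yl gives a 15-fold higher number from compound 3 to compound 4 (1.19 log units; beyond the scatter), the only large step so far. The same ring in place of 5-fluoropyridin-2-yl gives an 8.6-fold higher number from compound 2 to compound 4 (0.94 log units; beyond the scatter). Even a change from one five-membered aromatic ring to another counts, since 1H-1,2,4-triazol-1-yl in place of 1H-pyrazol-1-yl gives a 4.2-fold higher number from compound 1 to compound 4 (0.63 log units; beyond the scatter).

No measurement in hand explains why these steps are so large. Open too, as far as these compounds go, is how a plain phenyl ring or a 1H-imidazol-1-yl ring would read at this position, and whether an amino group on a five-membered ring would lower the number.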